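A few compounds are considered here, and "the series" means these few. Any claim that something is new, unique, unknown or untested is made for them only; others in the source may bear on it.

Measured in a functional assay on HEK293 cells for positive allosteric modulation of metabotropic glutamate receptor 5 (Homo sapiens), read by FLIPR and calcium flux; a higher number here means that more compound is needed for the effect, a lower number that less compound is needed:
compound 1 `O=C(COCc1ccccc1)N1CCN(c2ccccc2)CC1` — 7100 nM
compound 2 `O=C(COCc1ccccc1)N1CCN(c2ccc(F)cc2Cl)CC1` — 270 nM
compound 3 `O=C(COCc1cnccn1)N1CCN(c2ccc(Cl)cc2Cl)CC1` — 5200 nM

Compound 3 gives the second highest of the three numbers in this assay; its nearest neighbour is compound 1, within the scatter, while compound 2 sits far below it, beyond the scatter. Going by the values given here, the only step measured at a single position, a 26-fold lower number from compound 1 to compound 2 (1.42 log units; beyond the scatter), concerns the aryl group on the amine nitrogen in the ring and says nothing about the ether side. Compound 4 `O=C(COCc1cccs1)N1CCN(c2ccc(Cl)cc2Cl)CC1` differs from compound 3 only on that ether side: thiophen-2-yl in place of pyrazin-2-yl on a saturated chain carbon bound to an oxygen on a saturated carbon. Among the compounds with values here, no measured pair isolates this change. Within the data shown here, compound 2 and compound 3 differ in two places at once, so their values show only that compound 2 gives the lower number. Among the measured compounds shown here, with no direct precedent, a modest move toward a lower number is expected for compound 4, a 3.5-fold lower number from compound 3 to compound 4 (0.54 log units; beyond the scatter), carrying wide uncertainty. Compound 4 is estimated at 1500 nM in this assay, range 300 nM to 6000 nM.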

Compound 4, half-maximal effective concentration: > 310 nM
Compound 4: only a limit was reported; the forecaster's own chance of this, stated with the estimate: 5%; the middle value does not contradict the limit.
By their numbers in this assay, from the lowest: compound 2; then compounds 3 and 1 (each within the scatter of the next).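

In this assay, compound 4 gives > 310 nM, which is a limit and not a number. Going by these compounds alone, no step from compound 3 to compound 4 can be read from it. The compounds shown leave open how thiophen-2-yl and pyrazin-2-yl compare on the ether side of the shared core.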